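Boronic Acid Amides on Breast Cancer Cells: Isopropyl to Acetylphenyl

A few compounds are considered here, and "the series" means these few. Any claim that something is new, unique, unknown or untested is made for them only; others in the source may bear on it.

Measured compounds:
compound 1, `CC(C)(C)OC(=O)NCc1ccc(NC(=O)CCc2cccc3c2B(O)OC3)cc1`, 1300 nM
compound 2, `CC(C)c1cccc(NC(=O)CCc2cccc3c2B(O)OC3)c1`, 1600 nM
compound 3, `O=C(CCc1cccc2c1B(O)OC2)Nc1ccccc1-c1ccccc1`, 18000 nM

Three amides built on a shared core were tested in a functional assay on MDA-MB-231 cells (Homo sapiens) for antiproliferative activity, read by MTT assay, with a stated time of 72 h; on this read-out lower numbers stand for stronger inhibition and higher numbers for weaker inhibition. Compound 1 gives 1300 nM in this assay, and compound 2 gives 1600 nM, a difference that lies within the usual scatter, so the two cannot be ordered. Compound 3 stands apart: it gives 18000 nM, a number well beyond the scatter above that of compound 2. Compound 2 thus holds the second highest of the three numbers, close to compound 1 and far from compound 3.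

Compound 4, `CC(=O)c1cccc(-c2cccc(NC(=O)CCc3cccc4c3B(O)OC4)c2)c1`, has not yet been measured. It differs from compound 2 in one place: 3-acetylphenyl in place of isopropyl on an aromatic carbon. Among the measured compounds shown here, no pair of measured compounds reproduces this change, so the step has no direct precedent. Compound 3 carries an aromatic ring on the aniline as well and gives the weakest number seen, but its ring sits elsewhere, so it serves only as a loose warning. On balance, compound 4 is expected to give a somewhat higher number than compound 2, a step of a 1.9-fold higher number from compound 2 to compound 4 (0.27 log units; within the scatter), modest enough that it may stay within the scatter. The estimate for compound 4 in this assay is 3000 nM, with a range from 800 nM to 12000 nM.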

Compound 4, half-maximal inhibitory concentration: 52 nM
Estimate against measurement, compound 4: 58-fold (1.76 log units) above, outside the stated range (below it).
By their numbers in this assay, from the lowest: compound 4; then compounds 1 and 2 (each within the scatter of the next); then compound 3.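

In this assay, among the compounds shown here, the change from isopropyl to 3-acetylphenyl on an aromatic carbon, meta to a large group, gives a 31-fold lower number from compound 2 to compound 4 (1.49 log units; beyond the scatter) and so shows that this position accepts a much larger group with a large drop in the number, which the earlier compounds could not show, as no two of them differ in one place. The step replaces a group of 3 heavy atoms with no ring by one of 9 heavy atoms that holds a six-membered aromatic ring of carbon only and a carbonyl, so several features change together in this single replacement. Nothing measured here explains why the number falls so far on this change.

The compounds shown do not separate the part played by the added ring from that of the acetyl on it, as no plain phenyl stands among them at this position. They also leave open whether an amine or a carboxylic acid in place of the acetyl on this ring would keep the low number of compound 4.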